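The source may report more compounds than this note shows. Statements on the series, on what has been measured and on what is new or still open speak of the compounds shown alone.

In a toxicity assay on PC-12 cells (Rattus norvegicus) for cytotoxicity, read by MTT assay (a lower number here means a stronger inhibitor, a higher number a weaker inhibitor), two compounds have been measured so far:

- compound 1 `Cc1ccc(-n2nc(-c3ccc(C(F)(F)F)cc3O)nc2-c2ccccc2O)cc1` gives 113000 nM
- compound 2 `Oc1cc(C(F)(F)F)ccc1-c1nc(-c2ccccc2O)n(-c2cccc(C(F)(F)F)c2)n1` gives 49700 nM

Compound 1 has the higher number of the two, so it is the weaker inhibitor of this pair. Compound 3 `Cc1ccc(-n2nc(-c3ccc(C(F)(F)F)cc3O)nc2-c2ccccc2O)c(C)c1` is built from compound 1 with one small change, methyl in place of hydrogen on an aromatic carbon, turning 4-methylphenyl into 2,4-dimethylphenyl.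

For the measured compounds named here, only one measured step bears on this, a 2.3-fold lower number from compound 1 to compound 2 (0.36 log units; beyond the scatter). That modest step changed the same aryl group on the aromatic nitrogen, but it swapped one group for another rather than adding a single methyl. With so little evidence, only a small shift towards a lower number is expected, probably within the scatter. The estimated change is a 1.3-fold lower number from compound 1 to compound 3 (0.12 log units; within the scatter). For compound 3 the expected value is 85000 nM, with an estimated range of 40000 nM to 180000 nM.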

Compound 3, half-maximal inhibitory concentration: 231000 nM
Estimate against measurement, compound 3: 2.7-fold (0.43 log units) below, outside the stated range (above it).
By their numbers in this assay, from the lowest: compound 2; then compound 1; then compound 3.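

In this assay, one added methyl on an aromatic carbon, ortho to a large group and meta to a methyl group, turns 4-methylphenyl into 2,4-dimethylphenyl and gives a 2.0-fold higher number from compound 1 to compound 3 (0.31 log units; beyond the scatter), so this small change makes the compound a weaker inhibitor. The aryl group on the aromatic nitrogen can therefore move the number either way, and the widest gap among these compounds is a 4.6-fold higher number from compound 2 to compound 3 (0.67 log units; beyond the scatter), which sets 2,4-dimethylphenyl against 3-(trifluoromethyl)phenyl. Nothing available explains why the number rises at this position.

The compounds shown leave open whether this rise is specific to methyl or would also appear with a chlorine atom or a methoxy group on the same aromatic carbon. They also leave open whether methyl has the same effect on an aryl group without the 4-methyl.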